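The source may hold more compounds than are shown below. What is called first, only, known or untested is meant among the compounds shown, and "the series" means these compounds.

Measured compounds:
- compound 1, `CC(C)C(=O)N1CCC(CCCC(=O)c2ncco2)CC1`: 250 nM
- compound 2, `O=C(CCCC1CCN(Cc2ccccc2)CC1)c1ncco1`: 315 nM

Both were tested in an assay on isolated protein for inhibition of Fatty-acid amide hydrolase 1 (Homo sapiens); on this read-out lower numbers stand for stronger inhibition and higher numbers for weaker inhibition. Compound 2 has the highest of the two numbers, and its nearest neighbour is compound 1, which differs by a 1.3-fold higher number from compound 1 to compound 2 (0.10 log units; within the scatter); the two values therefore lie within the scatter of each other. Among the measured compounds shown here, the only measured step concerns the group on the ring nitrogen, not the benzyl ring itself.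

Compound 3, `Cc1ccc(CN2CCC(CCCC(=O)c3ncco3)CC2)cc1`, is not yet measured. It differs from compound 2 by methyl in place of hydrogen on an aromatic carbon. For the measured compounds named here, no measured pair shows this change, so nothing in the available data speaks directly to it. Going by the values given here, the one step that exists, a 1.3-fold higher number from compound 1 to compound 2 (0.10 log units; within the scatter), lies within the scatter and swaps a much larger group at a different place, so it gives no direction for the methyl. On that basis the number for compound 3 is expected to stay close to that of compound 2, with a step of a 1.1-fold lower number from compound 2 to compound 3 (0.02 log units; within the scatter) that is not expected to exceed the scatter. The estimate for compound 3 is 300 nM, within a range of 100 nM to 900 nM.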

Compound 3, half-maximal inhibitory concentration: 400 nM
The estimate for compound 3 lay 1.3-fold (0.12 log units) below the measured number, within the range that was stated.
By their numbers in this assay, from the lowest: compounds 1, 2 and 3 (each within the scatter of the next).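

Among the compounds shown here, with compound 3, the benzyl ring itself is altered for the first time: in this assay, a methyl on an aromatic carbon, para to a large group, gives a 1.3-fold higher number from compound 2 to compound 3 (0.10 log units; within the scatter). At this place on the ring, then, the added carbon cannot be told apart from hydrogen in this read-out, a finding the earlier pair could not give because it concerned only the group on the ring nitrogen. The larger exchange of 4-methylbenzyl for isopropylcarbonyl on that nitrogen gives a 1.6-fold higher number from compound 1 to compound 3 (0.20 log units; within the scatter), so this step also stays inside the scatter, and the three compounds cannot be ranked. No independent measurement bears on these results, and the reason for them stays unknown.

Going by these compounds, whether a different group on this aromatic carbon, such as methoxy, a carboxylic acid or a second phenyl ring, would give a step beyond the scatter remains open, as does the outcome of a methyl on the other carbons of the ring. The compounds shown also leave open what a longer chain leading to the carbonyl would do, and what a free amine on the ring would do in place of the benzyl or isopropylcarbonyl group.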